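Benzyl Ether Replacements for the Allyl Ether of Compound 1

The compounds below may be only part of what the source reports. "The series", "measured", "known", "first", "only" and "open" are said of these compounds alone.

Compound 1 `C=CCOc1ccc2c(=O)c(-c3cc(OC)c(OC)cc3OC)coc2c1` is the reference point of the series. In a functional assay on HCT-116 cells (Homo sapiens) for antiproliferative activity, read by MTT assay, with a stated time of 24 h (a lower number here means a stronger inhibitor, a higher number a weaker inhibitor), compound 1 gives 6600 nM, the highest number of the three measured compounds; compound 3 is the nearest to it and compound 2 the furthest. Compound 2 `COc1cc(OC)c(-c2coc3cc(OCc4ccc(Br)cc4)ccc3c2=O)cc1OC` gives 1980 nM in this assay, and compound 3 `COc1cc(OC)c(-c2coc3cc(OCc4ccc(C(F)(F)F)cc4)ccc3c2=O)cc1OC` gives 2440 nM. Both measured steps away from compound 1 lower the number and are modest: a 3.3-fold lower number from compound 1 to compound 2 (0.52 log units; beyond the scatter) and a 2.7-fold lower number from compound 1 to compound 3 (0.43 log units; beyond the scatter). Between the two benzyl ethers the difference is a 1.2-fold higher number from compound 2 to compound 3 (0.09 log units; within the scatter), so bromo and trifluoromethyl on the entering ring read alike within the scatter.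

Compound 4 `COc1cc(OC)c(-c2coc3cc(OCc4cccc(C(F)(F)F)c4)ccc3c2=O)cc1OC` has not been measured in this assay. Relative to compound 1 the change is 3-(trifluoromethyl)phenyl in place of vinyl on a saturated chain carbon bound to an oxygen on an aromatic ring. Compound 4 differs from compound 3 only in where the trifluoromethyl group sits on the entering ring; no measurement exists for that pair. The steps to compound 2 and to compound 3 bear directly on this change, and both were modest drops beyond the scatter. A step of comparable size is expected for compound 4: a 2.5-fold lower number from compound 1 to compound 4 (0.40 log units; beyond the scatter). Compound 4 is therefore estimated at 2600 nM, with a likely range from 1300 nM to 5500 nM.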

Compound 4, half-maximal inhibitory concentration: 3400 nM
Compound 4: the middle estimate sits 1.3-fold (0.12 log units) below what was measured; the measured number falls inside the stated range.
By their numbers in this assay, from the lowest: compounds 2, 3, 4 and 1 (each within the scatter of the next, the first and the last beyond it).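

In this assay, among these compounds, a 1.9-fold lower number from compound 1 to compound 4 (0.29 log units; within the scatter) stays within the scatter, so compound 4 is the first benzyl ether that cannot be told apart from the allyl ether of compound 1, whereas the steps to compound 2 and compound 3 both lie beyond it. Moving the trifluoromethyl group gives a 1.4-fold higher number from compound 3 to compound 4 (0.14 log units; within the scatter) and also stays within the scatter, as does the change of the whole entering group in a 1.7-fold higher number from compound 2 to compound 4 (0.23 log units; within the scatter), so the three benzyl ethers read alike and this position shows no measurable preference among 4-bromophenyl, 4-(trifluoromethyl)phenyl and 3-(trifluoromethyl)phenyl. No accompanying data explain these numbers or the difference in how the three steps from compound 1 read against the scatter.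

The compounds shown leave open how an unsubstituted benzyl ether or a longer chain carrying the same aromatic ring would read at this position. They also leave open whether an amine or a carboxylic acid on the entering ring would move the number further from that of compound 1 than the bromo and trifluoromethyl groups do.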